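The compounds below may be only part of what the source reports. "The series", "measured", "known", "first", "only" and "open" are said of these compounds alone.

Working notes on the series. Of the compounds shown here, three have so far been measured in a functional assay on HEp-2 cells (Homo sapiens) for inhibition, read by sulforhodamine B assay, with a stated time of 48 h; a higher number here means a weaker inhibitor, a lower number a stronger inhibitor. Compound 1 `O=c1c(C2N=C(c3ccccc3)SS2)coc2ccc(F)cc12` gives 98600 nM there. Compound 2 `O=c1c(C2N=C(c3ccccc3)SS2)coc2ccccc12` gives in this assay only a limit of the assay, > 100000 nM. Compound 3 `O=c1c(C(=S)Nc2ccccc2)coc2ccccc12` likewise gives in this assay only a limit of the assay, > 100000 nM. Two of the three measured values therefore sit at the limit of > 100000 nM in this assay, at which 2 of the 3 values shown sit, and compound 3 is known by that limit alone.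

Compound 4 `O=c1c(C(=S)Nc2ccccc2)coc2ccc(F)cc12` has not yet been measured in this assay. It differs from compound 3 by fluoro in place of hydrogen on an aromatic carbon. The same change is already on record between two measured compounds: compound 1 differs from compound 2 by fluoro in place of hydrogen on an aromatic carbon, and the two place descriptions agree word for word, so this is the same change rather than merely the same kind. The step it made in this assay was an at least 1.0-fold lower number from compound 2 to compound 1 (0.00 log units; that floor lies within the scatter); its true size cannot be pinned down because the limit of > 100000 nM in this assay, at which 2 of the 3 values shown sit, stands at one end of it. How the core of compound 3 differs from the core of compound 2 is not broken down here.

For compound 4 the step is expected to be a number no higher from compound 3 to compound 4 (the limit leaves the size open). That expectation rests on the measured step of an at least 1.0-fold lower number from compound 2 to compound 1 (0.00 log units; that floor lies within the scatter), which lies within the scatter, and on compound 3 starting from a limit, > 100000 nM. Compound 4 is accordingly estimated at 100000 nM, with a likely range from 50000 nM to 200000 nM, and an outcome reported only as a limit of the assay would not be surprising.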

Compound 4, half-maximal inhibitory concentration: > 100000 nM
Compound 4 was reported as a limit; the forecaster's own chance of this, stated with the estimate: 55%; the middle value sits exactly at the limit.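

No new step can be read between compound 3 and compound 4, because each of the two is known only by a limit of the assay: the limit of > 100000 nM in this assay, at which 3 of the 4 values shown sit. The compounds shown leave open how large the effect of fluoro in place of hydrogen on an aromatic carbon is for this pair, and where the true numbers of compound 3 and compound 4 lie in this assay.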